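The source may hold more compounds than are shown below. What is called first, only, known or untested is meant among the compounds shown, and "the series" means these compounds.

Compound 1, `CCOC(=O)C1=Cc2ccccc2OC1(OCc1cn(CC(=O)Nc2cccc(F)c2)nn1)C(F)(F)F`, gives in a functional assay on MCF7 cells (Homo sapiens) for inhibition, read by MTT assay, with a stated time of 24 h (on this read-out lower numbers stand for stronger inhibition and higher numbers for weaker inhibition), only a limit of the assay, > 150000 nM.
Compound 2, `CCOC(=O)C1=Cc2ccccc2OC1(OCc1cn(-c2ccccc2)nn1)C(F)(F)F`, gives in this assay likewise only a limit, > 150000 nM.
Compound 3, `CCOC(=O)C1=Cc2ccccc2OC1(OCc1cn(CC(=O)Nc2cccc(Cl)c2)nn1)C(F)(F)F`, gives in this assay 11600 nM.

Of these three compounds, compound 3 alone gives a number in this assay; the other two sit at the limit of > 150000 nM in this assay, at which 2 of the 3 values shown sit. The step from compound 1 to compound 3, chloro in place of fluoro on an aromatic carbon, reads an at least 12-fold lower number from compound 1 to compound 3 (1.11 log units; beyond the scatter), and the step from compound 2 to compound 3 reads an at least 12-fold lower number from compound 2 to compound 3 (1.11 log units; beyond the scatter). The pair of compound 1 and compound 2 gives a step that the two limits leave unreadable from compound 1 to compound 2.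

Compound 4, `CCOC(=O)C1=Cc2ccccc2OC1(OCc1cn(CC(=O)Nc2ccc(I)cc2Cl)nn1)C(F)(F)F`, has not yet been measured. It differs from compound 3 by 2-chloro-4-iodophenyl in place of 3-chlorophenyl on an amide-type nitrogen. Within the data shown here, none of the measured steps covers this change directly; the nearest, a halogen exchange, is the large step of an at least 12-fold lower number from compound 1 to compound 3 (1.11 log units; beyond the scatter), but compound 4 replaces the whole 3-chlorophenyl by 2-chloro-4-iodophenyl, so that step cannot be carried over with confidence. The step from compound 3 to compound 4 in this assay is therefore expected to stay small, a 1.5-fold lower number from compound 3 to compound 4 (0.16 log units; within the scatter), with no settled direction. For compound 4 in this assay the estimate is 8000 nM, expected to fall between 2500 nM and 40000 nM.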

Compound 4, half-maximal inhibitory concentration: 28100 nM
Beside the measured number, compound 4's estimate is 3.5-fold (0.55 log units) below it; the measured number falls inside the stated range.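

In this assay, the change on the amide-type nitrogen from 3-chlorophenyl to 2-chloro-4-iodophenyl gives a 2.4-fold higher number from compound 3 to compound 4 (0.38 log units; beyond the scatter), so this position keeps a readable number with a second halogen on the ring, though the number is modestly higher. That readable number is not confined to the 3-chlorophenyl group, as an at least 5.3-fold lower number from compound 1 to compound 4 (0.72 log units; beyond the scatter) and an at least 5.3-fold lower number from compound 2 to compound 4 (0.72 log units; beyond the scatter) both show, although the 3-fluorophenyl group of compound 1 goes against any rule that a halogenated phenyl on this nitrogen is enough. Compound 1 and compound 2 remain limits of the assay rather than numbers: the limit of > 150000 nM in this assay, at which 2 of the 4 values shown sit.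

Going by these compounds, it remains open whether the chloro or the iodo group of 2-chloro-4-iodophenyl carries the step, since the two enter together and 2-chlorophenyl and 4-iodophenyl on this nitrogen would be needed to separate them. Also open, on these data alone, is how a non-halogen group on this phenyl ring, such as a methoxy group, an amine or a carboxylic acid, would read in this assay.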